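Succinimide to sultam on the piperidine of compound 1

The compounds below may be only part of what the source reports. "The series", "measured", "known", "first", "only" and "open" are said of these compounds alone.

Measured compounds:
compound 1, `Cc1nc(N2CCC(N3C(=O)CCC3=O)CC2)nc2ccc(NC(=O)/C=C/c3ccc(OC(F)(F)F)cc3)cc12`, 40%
compound 2, `Cc1nc(N2CCC(N3CCCC3=O)CC2)nc2ccc(NC(=O)/C=C/c3ccc(Cl)cc3)cc12`, 83%

In an ADME assay on microsomes from liver (Mus musculus) for metabolic stability, with a stated time of 30 min (a higher number here means that more of the compound is left, a lower number that less of the compound is left), compound 1 gives 40%, the lowest of the two numbers. Compound 2 shows a value that is beyond the scatter higher, but it differs from compound 1 in two places at once, so the two values only show a gap, not a step attributable to one change.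

Compound 3, `Cc1nc(N2CCC(N3CCCS3(=O)=O)CC2)nc2ccc(NC(=O)/C=C/c3ccc(OC(F)(F)F)cc3)cc12`, has not been measured in this assay. It differs from compound 1 in one place: a group of 7 heavy atoms (3 carbon, 1 nitrogen, 2 oxygen, 1 sulfur; one five-membered non-aromatic ring with 2 hetero atoms) in place of a group of 7 heavy atoms (4 carbon, 1 nitrogen, 2 oxygen; one five-membered non-aromatic ring with 1 hetero atom), on a saturated ring carbon. On the numbers shown, no single change has been tested in isolation, so the direction of this step cannot be read from a measured pair.

Compound 3 is expected to sit above compound 1, with a step of a number 15 percentage points higher from compound 1 to compound 3 (beyond the scatter) in this assay, beyond the scatter but modest. The estimate for compound 3 is 55%, within a range from 30% to 80%.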

Compound 3, percent of the compound remaining: 83%
Compound 3: the middle estimate sits 28 percentage points below what was measured; the whole stated range lies below it.
By their numbers in this assay, from the lowest: compound 1; then compounds 2 and 3 (each within the scatter of the next).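

Exchanging the 2,5-dioxopyrrolidin-1-yl group on the saturated ring carbon for the five-membered ring with 2 hetero atoms, one of them sulfur, gives a number 43 percentage points higher from compound 1 to compound 3 (beyond the scatter) in this assay. Among these compounds, this is the first change at a single place, and it shows that this position alone can carry a large step while the rest of compound 1 stays unchanged. The two groups have the same count of heavy atoms, double bonds outside aromatic rings and hydrogen-bond acceptors, yet those shared counts do not keep the read-out the same. No measurement available here accounts for the step.

On these data alone, it remains open how other groups on this carbon, such as a primary amine, a carboxylic acid or a six-membered sultam, would behave. As far as these compounds go, it is also open whether the step would hold if chlorine replaced the trifluoromethoxy group elsewhere in the molecule.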